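A few compounds are considered here, and "the series" means these few. Any claim that something is new, unique, unknown or untested is made for them only; others in the source may bear on it.

Compound 1 `O=C1/C(=C/c2ccccc2)CCC/C1=C\c1ccc(O)cc1`, in an assay on isolated protein for inhibition of Alpha glucosidase (Homo sapiens), with stated times of 5 min and 15 min, tested at 50 uM; a higher number here means more inhibition at the concentration tested (going by the name of the read-out), a lower number less inhibition: 53%.
Compound 2 `COc1ccc(/C=C2\CCC/C(=C\c3ccccc3)C2=O)cc1`, in this assay: 31.4%.

Compound 2 stands lowest of the two numbers; its nearest neighbour is compound 1, higher by the step of a number 21.6 percentage points lower from compound 1 to compound 2 (beyond the scatter). Compound 3 `O=C1/C(=C/c2ccccc2)CCC/C1=C\c1ccc(Br)cc1` is to be measured in this assay. The change: bromo in place of methoxy on an aromatic carbon. Going by the values given here, the only step measured, a number 21.6 percentage points lower from compound 1 to compound 2 (beyond the scatter), bears on it loosely, since the oxygen it acted on now leaves altogether; no step shows a halogen entering. The expected step of a number 8.6 percentage points higher from compound 2 to compound 3 (within the scatter) is a modest rise, uncertain in sign. For compound 3 the estimate is 40%, in a range from 15% to 65%.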

Compound 3, a percentage reported as inhibition, at one concentration (the size of the read-out at that concentration, not a potency): 29.1%
The estimate for compound 3 lay 10.9 percentage points above the measured number; measured number inside the range.
By their numbers in this assay, from the lowest: compounds 3 and 2 (each within the scatter of the next); then compound 1.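

At the aromatic carbon para to a large group, in this assay, bromo in place of methoxy gives a number 2.3 percentage points lower from compound 2 to compound 3 (within the scatter), so this change does not separate the two groups. Bromo in place of hydroxy gives a number 23.9 percentage points lower from compound 1 to compound 3 (beyond the scatter), so a second replacement of hydroxy, not only methoxy, comes with a step beyond the scatter, leaving compound 1 apart from the other two. No measured evidence accounts for this.

As far as these compounds go, whether an amine or a carboxylic acid at this carbon would stand with compound 1 or with the other two remains open. So does the effect of any change on the unsubstituted phenyl ring.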